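The compounds below may be only part of what the source reports. "The series", "measured", "known", "first", "only" and "open" are said of these compounds alone.

compound 1 `Cc1ccc2[nH]c(C(=O)N[C@H]3CN(S(=O)(=O)c4ccccc4)C[C@@H]3C(=O)N[C@H]3CCCNC3)cc2c1` gives 0.04 10^-6 cm/s
compound 2 `O=C(N[C@H]1CN(S(=O)(=O)c2ccccc2)C[C@@H]1C(=O)N[C@H]1CCCNC1)c1cc(C2CC2)n[nH]1` gives 0.39 10^-6 cm/s
compound 3 `O=C(N[C@H]1CN(S(=O)(=O)c2ccccc2)C[C@@H]1C(=O)N[C@H]1CCCNC1)c1cn(C2CC2)cn1` gives 0.48 10^-6 cm/s

All three values come from an ADME assay on Caco-2 cells (Homo sapiens) for permeability, in the apical to basolateral direction, at pH 7.4; on this read-out lower numbers stand for lower permeability and higher numbers for higher permeability. Compound 3 shares the top of this small set with compound 2, and the gap between them is no real difference: a 1.2-fold higher number from compound 2 to compound 3 (0.09 log units; within the scatter). Compound 1 lies well under both.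

The next compound is compound 4 `O=C(N[C@H]1CN(S(=O)(=O)c2ccccc2)C[C@@H]1C(=O)N[C@H]1CCCNC1)c1nnc(-c2ccc(F)cc2)s1`, which keeps the shared core and changes only the group on the carbonyl carbon: a group of 12 heavy atoms (8 carbon, 2 nitrogen, 1 fluorine, 1 sulfur; one five-membered aromatic ring with 3 hetero atoms, one six-membered aromatic ring of carbon only) in place of a group of 8 heavy atoms (6 carbon, 2 nitrogen; one three-membered non-aromatic ring of carbon only, one five-membered aromatic ring with 2 hetero atoms), on a carbonyl carbon.

Going by the values given here, three measured steps bear on this, all at the same place. Replacing the 5-methyl-1H-indol-2-yl of compound 1 gave a 9.8-fold higher number from compound 1 to compound 2 (0.99 log units; beyond the scatter) and a 12-fold higher number from compound 1 to compound 3 (1.08 log units; beyond the scatter), both clear steps. Exchanging the two smaller groups gave a 1.2-fold higher number from compound 2 to compound 3 (0.09 log units; within the scatter). The entering group resembles the 5-methyl-1H-indol-2-yl of compound 1 in holding a six-membered aromatic ring of carbon only, so the value of compound 1 at 0.04 10^-6 cm/s marks the likely lower side. Among the compounds with values here, no measured compound carries the entering group itself, so this comparison is only a loose guide.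

A fall is expected, with the estimate being a 3.2-fold lower number from compound 3 to compound 4 (0.51 log units; beyond the scatter). The estimated value for compound 4 is 0.15 10^-6 cm/s, with an expected range from 0.04 10^-6 cm/s to 0.6 10^-6 cm/s.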

Compound 4, apparent permeability: < 0.03 10^-6 cm/s
Compound 4: only a limit was reported; the forecaster's own chance of this, stated with the estimate: 10%; middle value at least 5.0-fold (0.69 log units) from the limit.
By their numbers in this assay, from the lowest: compound 1; then compounds 2 and 3 (each within the scatter of the next). At a limit, below all of these: compound 4.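

In this assay compound 4 gives a limit of the assay and not a number: the limit of < 0.03 10^-6 cm/s in this assay, at which 1 of the 4 values shown sits.

Even so, the change at this position can be read against the two smaller groups, as the step of an at least 16-fold lower number from compound 3 to compound 4 (1.20 log units; beyond the scatter) and the step of an at least 13-fold lower number from compound 2 to compound 4 (1.11 log units; beyond the scatter) are both large and beyond the scatter, so the group on the carbonyl carbon can move this read-out well down as well as up. The step of an at least 1.3-fold lower number from compound 1 to compound 4 (0.12 log units; that floor lies within the scatter) has a floor within the scatter, so no order can be set between these two compounds; what the set does show is that both groups holding a six-membered aromatic ring of carbon only sit under the values of compound 2 and compound 3, and none of the four compounds goes against this.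

Going by these compounds, whether the low reading goes with the fluorine, the five-membered aromatic ring with 3 hetero atoms or simply the group of 12 heavy atoms stays open, and a partner with hydrogen, an amine or a carboxylic acid in place of the fluorine would help to separate these. How far compound 4 really lies from compound 1 also stays unresolved.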